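The compounds below may be only part of what the source reports. "The series", "measured", "known", "first", "only" and "open" are said of these compounds alone.

Compound 1, with structure `C=C1CCCC(C)(C)C1CC[C@]1(C)CC[C@@H]([C@@H](C)C(=O)O)OO1`, is an acid built on a shared core that carries a cyclic peroxide. In a functional assay on A549 cells (Homo sapiens) for inhibition (on this read-out lower numbers stand for stronger inhibition of growth and higher numbers for weaker inhibition of growth), compound 1 gives only a limit of > 10000 nM, not a number. That limit is where compound 1 stands: the limit of > 10000 nM in this assay, at which 1 of the 2 values shown sits. Compound 2, the methyl ester `C=C1CCCC(C)(C)C1CC[C@]1(C)CC[C@H]([C@@H](C)C(=O)OC)OO1`, belongs to the same family; in this assay compound 2 gives 640 nM. Compound 3, with structure `C=C1CCCC(C)(C)C1CC[C@@]1(C)CC[C@H]([C@@H](C)C(=O)O)OO1`, has not yet been measured. It differs from compound 1 as follows: the two compounds have the same atoms and bonds; at least one stereo element is drawn with a configuration in one of them and without one in the other: 2 of 4 stereo elements differ; a stereocentre at a saturated ring carbon is drawn R in compound 1 and S in compound 3; a stereocentre at a saturated ring carbon is drawn S in compound 1 and R in compound 3. Going by the values given here, no measured step between two compounds that differ only in this way is available, so the size and direction of the change can only be guessed. Because compound 1 sits at the limit > 10000 nM, a move toward stronger inhibition is the only one that could be seen at all. The expected step from compound 1 to compound 3 is an at least 3.3-fold lower number from compound 1 to compound 3 (0.52 log units; beyond the scatter). Compound 3 is estimated at 3000 nM, within a range from 500 nM to 20000 nM.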

Compound 3, concentration for 50% growth inhibition: 3050 nM
Compound 3: the middle estimate sits 1.0-fold (0.01 log units) below what was measured; the range from low to high includes it.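

In this assay compound 1 gives > 10000 nM as a limit of the assay and not as a number. Reversing two stereocentres at saturated ring carbons, while all atoms and bonds stay the same, gives an at least 3.2-fold lower number from compound 1 to compound 3 (0.51 log units; beyond the scatter) and brings the acid within the measurable range. This shows that a carboxylic acid on this shared core can inhibit growth, and that the spatial arrangement at these two ring carbons alone can separate a measurable acid from one that reaches only the limit.

On these data alone, since the two stereocentres change together, their separate contributions remain unknown, and the limit leaves the full size of the step open. It is also unclear how an amide or a longer ester chain in place of the acid would behave with the arrangement of compound 3.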